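Benzyl in place of propyl on an amide: expected cytotoxicity

The source may report more compounds than this note shows. Statements on the series, on what has been measured and on what is new or still open speak of the compounds shown alone.

Of the compounds shown here, three have been tested in an ADME assay on L929 cells (Mus musculus) for cytotoxicity, read by resazurin assay, with a stated time of 72 h; on this read-out higher numbers stand for weaker inhibition and lower numbers for stronger inhibition. Compound 1 `COc1ccc(Sc2cn(-c3ccc4c(c3)B(O)OC4)c3ccccc23)cc1` gives > 10 ug/mL, which is a limit of the assay rather than a number. Compound 2 `OB1OCc2ccc(-n3cccc3)cc21` likewise gives a limit, > 10 ug/mL. Compound 3 `CCCNC(=O)c1cccn1-c1ccc2c(c1)B(O)OC2` also gives a limit, > 10 ug/mL. Within the data shown here, the one change between measured compounds, a step that the two limits leave unreadable from compound 2 to compound 3, cannot be sized: the limit of > 10 ug/mL in this assay, at which 3 of the 3 values shown sit. Compound 4 `O=C(NCc1ccccc1)c1cccn1-c1ccc2c(c1)B(O)OC2` differs from compound 3 by phenyl in place of ethyl on a saturated chain carbon bound to an amide-type nitrogen. Among the measured compounds shown here, no measured step bears directly on this change, and the only step on record is unreadable, so nothing points to a step beyond the scatter. Compound 4 is therefore expected to give 15 ug/mL, in the range 5 ug/mL to 50 ug/mL, most likely again reported only as a limit. The step that the limit leaves unreadable from compound 3 to compound 4 is the estimated consequence.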

Compound 4, half-maximal inhibitory concentration: > 10 ug/mL
Compound 4 was reported as a limit (the forecaster's own chance of this, stated with the estimate: 75%); the middle value lies beyond the limit too.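

Compound 3 and compound 4 both sit at a limit rather than a number, so no step between them can be read: the limit of > 10 ug/mL in this assay, at which 4 of the 4 values shown sit.

The compounds shown leave open how far beyond that limit each one lies in this assay.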